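Cardiac cell toxicity across three related compounds

The source may hold more compounds than are shown below. What is called first, only, known or untested is meant among the compounds shown, and "the series" means these compounds.

compound 1 `COc1ccccc1Cc1coc2cccc(O)c2c1=O` — > 100000 nM
compound 2 `COc1ccc(Cc2coc3cc(OCCCCCl)cc(O)c3c2=O)cc1` — > 100000 nM

In a functional assay on H9c2 cells (Mus musculus) for cytotoxicity against H9c2 (Rattus norvegicus), read by MTT assay, with a stated time of 24 h (a higher number here means that more compound is needed for the effect, a lower number that less compound is needed), compound 1 gives > 100000 nM, which is a limit of the assay rather than a number. Compound 2 gives > 100000 nM, likewise only a limit. Among the compounds with values here, compound 2 therefore stands at the limit of > 100000 nM in this assay, at which 2 of the 2 values shown sit, and no measured step between any two compounds is available. Compound 3 `CCC(=O)Oc1cc(O)c2c(=O)c(Cc3ccc(OC)cc3)coc2c1` differs from compound 2 by propanoyl in place of 4-chlorobutyl on an oxygen on an aromatic ring. With both measured values sitting at the limit, no shift beyond the usual scatter is expected. Compound 3 is estimated at 150000 nM, in a range from 50000 nM to 500000 nM. This estimate corresponds to an expected step that the limit leaves unreadable from compound 2 to compound 3, most likely reported again as a limit.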

Compound 3, half-maximal effective concentration: > 100000 nM
Compound 3: a limit, no number (the forecaster's own chance of this, stated with the estimate: 80%); the middle value is on the limit's open side.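

Within the data shown here, compound 3, like compound 2, ends at a limit rather than a number, so no step between compound 2 and compound 3 can be read: the limit of > 100000 nM in this assay, at which 3 of the 3 values shown sit. The compounds shown leave open what concentration any of them would need to reach the effect in this assay, and whether propanoyl and 4-chlorobutyl differ there at all.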